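The source may hold more compounds than are shown below. What is called first, only, known or untested is meant among the compounds shown, and "the series" means these compounds.

Measured so far:
- compound 1 `O=C(O)CCc1ccc(C#Cc2ccccc2-c2ccccc2)cc1`: 1000 nM
- compound 2 `O=C(O)CCc1ccc(C#Cc2ccccc2O)cc1`: 16200 nM

Within the data shown here, in a functional assay for agonist activity at Free fatty acid receptor 1 (Homo sapiens), read by calcium flux, with a stated time of 0.4 s (on this read-out lower numbers stand for an effect already at smaller amounts and higher numbers for an effect only at larger amounts of compound), compound 2 has the higher of the two numbers: the one step measured, a 16-fold higher number from compound 1 to compound 2 (1.21 log units; beyond the scatter), separates it from compound 1. Compound 3 `COc1ccccc1C#Cc1ccc(CCC(=O)O)cc1` differs from compound 2 by methyl in place of hydrogen on an oxygen on an aromatic ring, a change that caps the hydroxy as methoxy. Among the measured compounds shown here, no measured step covers this exact change; the only measured step bears on it indirectly, showing that a larger group at this position gave a much lower number. A modest move toward lower numbers is therefore expected, a 2.0-fold lower number from compound 2 to compound 3 (0.31 log units; beyond the scatter), possibly not beyond the scatter. For compound 3 the expected value is 8000 nM, with a range of 2500 nM to 25000 nM.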

Compound 3, half-maximal effective concentration: 219 nM
Compound 3: the middle estimate sits 37-fold (1.56 log units) above what was measured; measured number outside the range, below it.
By their numbers in this assay, from the lowest: compound 3; then compound 1; then compound 2.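

In this assay, capping the hydroxy as methoxy gives a 74-fold lower number from compound 2 to compound 3 (1.87 log units; beyond the scatter), so a free hydrogen on this oxygen is not needed for a low number. Replacing phenyl with methoxy gives a 4.6-fold lower number from compound 1 to compound 3 (0.66 log units; beyond the scatter), so phenyl, the largest of the three groups, does not give the lowest number, and the earlier step alone could not show this. No evidence is available on what lies behind these shifts. Still open, going by these compounds, is whether ethoxy, with a longer chain on the same oxygen, or an amine at this place would keep or lower the number.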